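Replacing cyclohexylmethyl with 2-fluorophenyl on the amide

The compounds below may be only part of what the source reports. "The series", "measured", "known", "first", "only" and "open" are said of these compounds alone.

Measured compounds in a functional assay on BaF3 cells (Mus musculus) for antiproliferative activity, read by CCK-8 assay and cell counting, with a stated time of 76 h; a higher number here means a weaker inhibitor, a lower number a stronger inhibitor
- compound 1 `COc1cc2nccc(Oc3ccc(Nc4nn(C)cc4C(=O)NC4CCCCCCC4)cc3)c2cc1C(N)=O` gives 3210 nM
- compound 2 `COc1cc2nccc(Oc3ccc(Nc4nn(C)cc4C(=O)N4CCCC5CCCCC54)cc3)c2cc1C(N)=O` gives 4330 nM
- compound 3 `COc1cc2nccc(Oc3ccc(Nc4nn(C)cc4C(=O)NCC4CCCCC4)cc3)c2cc1C(N)=O` gives a limit (> 10000 nM)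

Compound 3 therefore has no exact number, only a limit (> 10000 nM) in this assay. Compound 4 `COc1cc2nccc(Oc3ccc(Nc4nn(C)cc4C(=O)Nc4ccccc4F)cc3)c2cc1C(N)=O` carries 2-fluorophenyl in place of cyclohexylmethyl on an amide-type nitrogen. The closest guides are two steps beyond the scatter (an at least 3.1-fold higher number from compound 1 to compound 3 (0.49 log units; beyond the scatter) and an at least 2.3-fold higher number from compound 2 to compound 3 (0.36 log units; beyond the scatter)), whereas another stays within it (a 1.3-fold higher number from compound 1 to compound 2 (0.13 log units; within the scatter)). Among the measured compounds shown here, none of the measured compounds has an aromatic ring on this amide, so the guidance is rough. The expected step is modest and toward a lower number (an at least 2.2-fold lower number from compound 3 to compound 4 (0.34 log units; beyond the scatter)). Compound 4 is estimated at 4500 nM (expected range 1000 nM to 15000 nM).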

Compound 4, half-maximal inhibitory concentration: 1710 nM
Compound 4: the middle estimate sits 2.6-fold (0.42 log units) above what was measured; the range from low to high includes it.
By their numbers in this assay, from the lowest: compounds 4, 1 and 2 (each within the scatter of the next, the first and the last beyond it). At a limit, above all of these: compound 3.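

With 2-fluorophenyl on this amide-type nitrogen, this assay shows the first aromatic ring at this position, with an at least 5.8-fold lower number from compound 3 to compound 4 (0.76 log units; beyond the scatter), so such a ring is tolerated here. Against the saturated ring groups the picture splits, with a 2.5-fold lower number from compound 2 to compound 4 (0.40 log units; beyond the scatter) but only a 1.9-fold lower number from compound 1 to compound 4 (0.27 log units; within the scatter), which leaves compound 4 and compound 1 not told apart. The first of these steps starts from a limit for compound 3, not from a number: the limit of > 10000 nM in this assay, at which 1 of the 4 values shown sits.

Going by these compounds, what a plain phenyl, a 2-chlorophenyl or a pyridyl ring would give on this amide remains open. The part played by the fluorine therefore cannot be separated from that of the aromatic ring.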